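Nitrofuran amides on Vero cells: from chloro to dimethylamino

This account rests on a few compounds, and the source may have more. Where it says the series, first, only, none or still open, it means among the compounds named here.

Measured so far in an ADME assay on Vero cells (Chlorocebus sabaeus) for cytotoxicity, read by MTT assay, with a stated time of 48 h; a lower number here means that less compound is tolerated, a higher number that more compound is tolerated:
- compound 1 `CC(NC(=O)c1ccc([N+](=O)[O-])o1)c1ccccc1` gives 24000 nM
- compound 2 `O=C(NC1(c2ccccc2)CC1)c1ccc([N+](=O)[O-])o1` gives 46000 nM
- compound 3 `CC(C)(NC(=O)c1ccc([N+](=O)[O-])o1)c1ccc(Cl)cc1` gives 81000 nM

All three compounds share a nitrofuran amide core and differ only in the group attached to the amide nitrogen. Compound 3 shows the highest number of the three in this assay. Its gap to compound 2 lies within the scatter of repeated measurements, so the two cannot be told apart; its gap to compound 1 lies beyond the scatter, so compound 3 is tolerated by the cells at a clearly higher concentration than compound 1.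

Compound 4 `CN(C)c1ccc(C(C)(C)NC(=O)c2ccc([N+](=O)[O-])o2)cc1` is the next compound and has not yet been measured. It differs from compound 3 in one place: dimethylamino in place of chloro on an aromatic carbon. For the measured compounds named here, no pair of measured compounds shows this kind of exchange, so there is no measured step to lean on. With nothing in the data pointing either way, the expected step in this assay from compound 3 to compound 4 is none beyond the scatter, that is a 1.2-fold lower number from compound 3 to compound 4 (0.06 log units; within the scatter). Compound 4 is therefore estimated at 70000 nM, with a range from 30000 nM to 160000 nM.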

Compound 4, half-maximal cytotoxic concentration: 79000 nM
Beside the measured number, compound 4's estimate is 1.1-fold (0.05 log units) below it; low and high end bracket the measured number.
By their numbers in this assay, from the lowest: compounds 1, 2, 4 and 3 (each within the scatter of the next, the first and the last beyond it).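

In this assay, the exchange of chloro for dimethylamino on an aromatic carbon, para to a large group, gives a 1.0-fold lower number from compound 3 to compound 4 (0.01 log units; within the scatter) and so leaves the tolerated concentration unchanged as far as this assay can tell. For the compounds shown here, this is the first measured step at this position, since the earlier compounds differ from one another only in the group on the amide nitrogen and offered no view of a change on the aromatic ring. It shows that a single chlorine atom can give way to a group of three heavy atoms, including a nitrogen counted as a hydrogen-bond acceptor, with no change in the read-out that stands out from the scatter, though nothing measured here explains this outcome.

One exchange cannot show how much this position tolerates in general, and a carboxylic acid, a primary amine or a longer carbon chain in the same place could give a different result. On these data alone, it also remains open whether dimethylamino would give the same small step on the aromatic ring of compound 1 or compound 2, whose groups on the amide nitrogen differ from that of compound 3.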